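The source may report more compounds than this note shows. Statements on the series, on what has been measured and on what is new or still open speak of the compounds shown alone.

Measured compounds:

compound 1 `C1=C(c2cncc(Oc3ccccc3)c2)CC2CNCC1C2` – 1.9 nM
compound 2 `COc1ccc(Oc2cncc(C3=CC4CNCC(C3)C4)c2)cc1` – 27 nM
compound 3 `COc1cncc(C2=CC3CNCC(C2)C3)c1` – 14.3 nM

All three were tested in an in vitro assay on SH-SY5Y cells for displacement of a labelled ligand from Neuronal acetylcholine receptor; alpha3/beta4 (Homo sapiens); on this read-out lower numbers stand for stronger inhibition and higher numbers for weaker inhibition. Compound 1 gives 1.9 nM, compound 2 gives 27 nM and compound 3 gives 14.3 nM, so compound 1 stands apart from the other two, while compound 2 and compound 3 lie within the scatter of each other, as a 1.9-fold lower number from compound 2 to compound 3 (0.28 log units; within the scatter) shows.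

Compound 2 and compound 3 differ in their cores in this way: methyl in place of 4-methoxyphenyl on an oxygen on an aromatic ring. Compound 1 arises from compound 2 by the change (hydrogen in place of methoxy on an aromatic carbon), and that step is a 14-fold lower number from compound 2 to compound 1 (1.15 log units; beyond the scatter), a large step. The unmeasured compound 4 `C1=C(c2cccnc2)CC2CNCC1C2` arises from compound 3 by hydrogen in place of methoxy on an aromatic carbon. This is the same kind of change as from compound 2 to compound 1, but not the same: in compound 2 the methoxy leaves a six-membered aromatic ring of carbon only, para to a large group, whereas in compound 3 it leaves a six-membered aromatic ring with one nitrogen, two atoms from the ring nitrogen and meta to a group of nine heavy atoms.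

For compound 4 a step toward a lower number is expected, though a smaller one than a 14-fold lower number from compound 2 to compound 1 (1.15 log units; beyond the scatter), because that earlier step a 14-fold lower number from compound 2 to compound 1 (1.15 log units; beyond the scatter) was made at a different place; the estimated step is a 2.0-fold lower number from compound 3 to compound 4 (0.31 log units; beyond the scatter). Compound 4 is therefore estimated at 7 nM in this assay, with a likely range from 2.5 nM to 25 nM.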

Compound 4, inhibition constant: 12 nM
Estimate against measurement, compound 4: 1.7-fold (0.23 log units) below; the measured number falls inside the stated range.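

In this assay, hydrogen in place of methoxy on the six-membered aromatic ring with one nitrogen gives a 1.2-fold lower number from compound 3 to compound 4 (0.08 log units; within the scatter), a step too small to read as a real change, whereas hydrogen in place of phenoxy on that same ring gives a 6.3-fold higher number from compound 1 to compound 4 (0.80 log units; beyond the scatter). The same swap of methoxy for hydrogen therefore does not carry its size from one core to the other, and a step seen at one place in this series cannot simply be copied to another: the same change on two cores in this assay, a 14-fold lower number (1.15 log units; beyond the scatter) from compound 2 to compound 1 and a 1.2-fold lower number (0.08 log units; within the scatter) from compound 3 to compound 4, 12-fold (1.08 log units) apart, beyond the scatter of two such steps. What this does not show is the reason for the gap, as the two methoxy groups sit on different rings, and two pairs of compounds give no general rule for other groups or other places.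

The compounds shown leave open how other groups on the ring with one nitrogen, such as an amine, a carboxylic acid or a longer ether chain, would read in this assay. Also open, on these data alone, is whether a phenoxy ring carrying a chlorine or an amine in place of the methoxy of compound 2 would give a step as large as the methoxy one.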